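Side-chain variation and metabolic stability in one series

The compounds below may be only part of what the source reports. "The series", "measured", "known", "first", "only" and "open" are said of these compounds alone.

Values in an ADME assay on S9 fraction from liver (Homo sapiens) for metabolic stability, read by LC-MS, using NADPH, with stated times of 5 min and 60 min, tested at 5 uM; on this read-out lower numbers stand for a less stable compound and higher numbers for a more stable compound:
Compound 1 `COc1cc(C2CN(C(=O)c3cc(OCCO)ccn3)C2)ccc1OCc1ccc(C2CC2)cc1`: 47%
Compound 2 `COc1cc(C2CN(C(=O)c3cc(OC[C@H](O)CO)ccn3)C2)ccc1OCc1ccc(C2CC2)cc1`: 64%
Compound 3 `COc1cc(C2CN(C(=O)c3cc(OCCCC(C)(C)C(=O)O)ccn3)C2)ccc1OCc1ccc(C2CC2)cc1`: 81%

Compound 2 stands second highest of the three, with a number 17 percentage points higher from compound 1 to compound 2 (beyond the scatter) and a number 17 percentage points higher from compound 2 to compound 3 (beyond the scatter) framing it on either side; the span from compound 1 to compound 3 is a number 34 percentage points higher from compound 1 to compound 3 (beyond the scatter).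

Compound 4 `COc1cc(C2CN(C(=O)c3cc(COC[C@H](O)CO)ccn3)C2)ccc1OCc1ccc(C2CC2)cc1` differs from compound 2 by (2,3-dihydroxypropoxy)methyl in place of 2,3-dihydroxypropoxy on an aromatic carbon. Both steps touching this chain, from compound 1 to compound 2 and from compound 2 to compound 3, were modest and upward, yet each altered what the chain carries; here the counted donors and acceptors stay the same and one carbon enters. For the measured compounds named here, no step of this kind has been measured, so the expected step is small, a number 2 percentage points lower from compound 2 to compound 4 (within the scatter), likely within scatter. Compound 4 is expected to give 62%, ranging from 47% to 77%.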

Compound 4, percent of the compound remaining: 62%
Compound 4: the middle estimate sits on the measured number at the digits printed, and the stated range covers the measured number.
By their numbers in this assay, from the lowest: compound 1; then compounds 4 and 2 (each within the scatter of the next); then compound 3.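

In (this assay), a ring-bound carbon in place of the ring-bound oxygen, with the chain one carbon longer, leaves the read-out unchanged within the scatter (a number 2 percentage points lower from compound 2 to compound 4 (within the scatter)). Compound 4 therefore keeps the standing of compound 2 against the other two compounds (a number 15 percentage points higher from compound 1 to compound 4 (beyond the scatter); a number 19 percentage points lower from compound 3 to compound 4 (beyond the scatter)). Nothing available accounts for the size of these steps.

On these data alone, it remains open whether a carboxylic acid or an amine on the (2,3-dihydroxypropoxy)methyl chain would tolerate this linkage equally, and whether a longer chain would do the same.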